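Trimming the Side Chain of Compound 1

The source may hold more compounds than are shown below. What is called first, only, known or untested is meant among the compounds shown, and "the series" means these compounds.

Compound 1 `CCOCCn1c(N2CCN(C)CC2)nc2ccccc21` is the starting point. In a functional assay on ileum for inhibition of histamine H1 receptor (Cavia porcellus) (on this read-out lower numbers stand for stronger inhibition and higher numbers for weaker inhibition), compound 1 gives 10 nM. Compound 2 `CCCCN1CCCN(c2nc3ccccc3n2CCOCC)CC1` gives 8.4 nM in this assay, and the two numbers lie within the scatter of each other, so compound 1 holds the higher of the two numbers without being set apart from compound 2. Compound 3 `CCCn1c(N2CCN(C)CC2)nc2ccccc21` differs from compound 1 in one place: methyl in place of ethoxy on a saturated chain carbon, two bonds along the chain from an aromatic nitrogen. Among the measured compounds shown here, no measured pair shows this change, so the step is expected to stay within the scatter, at a 1.2-fold higher number from compound 1 to compound 3 (0.08 log units; within the scatter). Compound 3 is therefore estimated at 12 nM, with a range from 5 nM to 30 nM.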

Compound 3, half-maximal inhibitory concentration: 380 nM
Compound 3: the middle estimate sits 32-fold (1.50 log units) below what was measured; the whole stated range lies below it.
By their numbers in this assay, from the lowest: compounds 2 and 1 (each within the scatter of the next); then compound 3.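

Swapping ethoxy for methyl on a saturated chain carbon, two bonds along the chain from an aromatic nitrogen, gives a 38-fold higher number from compound 1 to compound 3 (1.58 log units; beyond the scatter) in this assay. Among the compounds shown here, compounds 1 and 2 both carry the 2-ethoxyethyl chain, so only this step shows that the read-out depends strongly on this part of the molecule. Nothing available explains why this step is so large.

The change shortens the chain and removes its oxygen together, so the two effects cannot be separated. A butyl chain or a 2-methoxyethyl chain at this place could help tell them apart.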